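This account rests on a few compounds, and the source may have more. Where it says the series, first, only, none or still open, it means among the compounds named here.

Measured so far, in an in vitro functional assay on 1321-N1 cells for agonist activity at P2Y purinoceptor 6 (Homo sapiens); a lower number here means that less compound is needed, a higher number that more compound is needed for the effect:
compound 1 `O=C(O)CSc1ccn([C@@H]2O[C@H](COP(=O)(O)OP(=O)(O)O)[C@@H](O)[C@H]2O)c(=O)n1` — 1700 nM
compound 2 `O=C(O)CCCSc1ccn([C@@H]2O[C@H](COP(=O)(O)OP(=O)(O)O)[C@@H](O)[C@H]2O)c(=O)n1` — 8800 nM
compound 3 `NC(=O)CSc1ccn([C@@H]2O[C@H](COP(=O)(O)OP(=O)(O)O)[C@@H](O)[C@H]2O)c(=O)n1` — 18000 nM

Compound 3 stands at the highest of the three numbers in this assay: a 2.0-fold higher number from compound 2 to compound 3 (0.31 log units; beyond the scatter) and an 11-fold higher number from compound 1 to compound 3 (1.02 log units; beyond the scatter) both end at it. Compound 4 `C=CCSc1ccn([C@@H]2O[C@H](COP(=O)(O)OP(=O)(O)O)[C@@H](O)[C@H]2O)c(=O)n1` differs from compound 3 by vinyl in place of carbamoyl on a saturated chain carbon bound to a sulfur; the side chain thus keeps no hydrogen-bond donor or acceptor. For the measured compounds named here, no measured step removes both at once. The nearest are an 11-fold higher number from compound 1 to compound 3 (1.02 log units; beyond the scatter), which swapped the acid for an amide, and a 2.0-fold higher number from compound 2 to compound 3 (0.31 log units; beyond the scatter), the chain swap; both moved toward higher numbers once carboxy was gone. A modest further rise is therefore expected, a 1.4-fold higher number from compound 3 to compound 4 (0.14 log units; within the scatter), with wide uncertainty. Compound 4 is estimated at 25000 nM, in the range 8000 nM to 80000 nM.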

Compound 4, half-maximal effective concentration: 560 nM
Estimate against measurement, compound 4: 45-fold (1.65 log units) above; the measured number lies below the stated range.
By their numbers in this assay, from the lowest: compound 4; then compound 1; then compound 2; then compound 3.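

Replacing (carbamoyl)methyl-type side chains with allylsulfanyl gives the lowest number of the four in this assay (a 32-fold lower number from compound 3 to compound 4 (1.51 log units; beyond the scatter)), and the same holds against the two acids (a 16-fold lower number from compound 2 to compound 4 (1.20 log units; beyond the scatter)) and (a 3.0-fold lower number from compound 1 to compound 4 (0.48 log units; beyond the scatter)). Carboxy is therefore not required for a low number on this saturated chain carbon bound to a sulfur, and its loss does not by itself raise the number, since compound 3 rises while compound 4 falls. No evidence on the cause of this change is available here.

Going by these compounds, it remains open whether the vinyl double bond matters, which a saturated propyl chain would test. A longer alkenyl chain or a terminal amine at this place is equally unresolved.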